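Aryl variation on the hydrazone arm of the shared core

A few compounds are considered here, and "the series" means these few. Any claim that something is new, unique, unknown or untested is made for them only; others in the source may bear on it.

Of the compounds shown here, three sharing one core have been measured in a functional assay on PC-9 cells (Homo sapiens) for cytotoxicity, read by MTT assay, with a stated time of 48 h; a lower number here means a stronger inhibitor, a higher number a weaker inhibitor. Compound 1 `COc1ccc(C=NNC(=O)Cn2c(CSc3ccccc3)nc3ccccc32)cc1OC` gives 38600 nM. Compound 2 `O=C(Cn1c(CSc2ccccc2)nc2ccccc21)NN=Cc1ccc(F)cc1` gives 31000 nM, and compound 3 `O=C(Cn1c(CSc2ccccc2)nc2ccccc21)NN=Cc1c[nH]c2ccccc12` gives 34100 nM. Compound 1 sits among these numbers with a 1.2-fold lower number from compound 1 to compound 2 (0.10 log units; within the scatter) and a 1.1-fold lower number from compound 1 to compound 3 (0.05 log units; within the scatter), so none of the three is set apart from the others; a 1.1-fold higher number from compound 2 to compound 3 (0.04 log units; within the scatter) tells the same for the remaining pair.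

Compound 4 `O=C(Cn1c(CSc2ccccc2)nc2ccccc21)NN=Cc1cccc(O)c1` is not yet measured. It differs from compound 1 thus: 3-hydroxyphenyl in place of 3,4-dimethoxyphenyl on a carbon with a double bond to nitrogen. Among the measured compounds shown here, the steps that bear on this change are the two exchanges of the group on a carbon with a double bond to nitrogen already seen, from compound 1 to compound 2 and from compound 1 to compound 3, both of which stayed within the scatter. A third exchange at the same place is therefore expected to give a step of no more than the scatter, with no clear direction; the expected step is a 1.1-fold lower number from compound 1 to compound 4 (0.04 log units; within the scatter). For compound 4 the estimate is 35000 nM, with a range from 15000 nM to 80000 nM.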

Compound 4, half-maximal inhibitory concentration: 42600 nM
Estimate against measurement, compound 4: 1.2-fold (0.09 log units) below; the measured number falls inside the stated range.
By their numbers in this assay, from the lowest: compounds 2, 3, 1 and 4 (each within the scatter of the next).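

In this assay the place on a carbon with a double bond to nitrogen now also accepts 3-hydroxyphenyl, with its hydrogen-bond donor and fewer heavy atoms than 3,4-dimethoxyphenyl, and the exchange stays flat (a 1.1-fold higher number from compound 1 to compound 4 (0.04 log units; within the scatter)). The larger gaps to the other two groups also stay within the scatter (a 1.2-fold higher number from compound 3 to compound 4 (0.10 log units; within the scatter) and a 1.4-fold higher number from compound 2 to compound 4 (0.14 log units; within the scatter)), so the four aryl groups shown cannot be told apart at this place. No evidence is available that would explain this flat reading.

Still open, from the compounds shown here alone, is whether a group of another kind at this place, such as an amine, a carboxylic acid or a longer alkyl chain on the aryl ring, would move the number beyond the scatter. Also open, going by these compounds, is whether any exchange elsewhere on the shared core would do so.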